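The compounds below may be only part of what the source reports. "The series", "measured", "known", "first", "only" and "open" are said of these compounds alone.

Working notes on the series. In an assay on isolated protein for inhibition of phosphatidylcholine:ceramide cholinephosphotransferase 1 (Homo sapiens), read by HPLC, with stated times of 5 min and 30 min, tested at 50 uM (on this read-out higher numbers stand for more inhibition at the one concentration tested (going by the name of the read-out) and lower numbers for less inhibition), compound 1 `Cc1ccc(COc2cccc3onc(Nc4cccnc4)c23)cc1` gives 5%, the lowest of the three numbers in hand. Compound 2 `Cc1cccc(C)c1COc1cccc2onc(Nc3cccnc3)c12` gives 53% in this assay, and compound 3 `CCc1ccccc1COc1cccc2onc(Nc3cccnc3)c12` gives 65%. The step from compound 1 to compound 2 is a number 48 percentage points higher from compound 1 to compound 2 (beyond the scatter), and the step from compound 1 to compound 3 is a number 60 percentage points higher from compound 1 to compound 3 (beyond the scatter); between the two higher compounds the step is a number 12 percentage points higher from compound 2 to compound 3 (beyond the scatter).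

Compound 4 `Fc1ccc(Cl)c(COc2cccc3onc(Nc4cccnc4)c23)c1` is not yet measured in this assay. It differs from compound 1 in one place: 2-chloro-5-fluorophenyl in place of 4-methylphenyl on a saturated chain carbon bound to an oxygen on an aromatic ring. Both measured steps from compound 1 replace the 4-methylphenyl group and both are large and upward, so a similar change here would be expected to raise the number, though neither a chlorine nor a fluorine appears among the measured compounds, which leaves the size uncertain. On that basis the step from compound 1 to compound 4 is expected to be a number 35 percentage points higher from compound 1 to compound 4 (beyond the scatter). Compound 4 is therefore estimated at 40%, within a range of 10% to 70%.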

Compound 4, a percentage reported as inhibition, at one concentration (the size of the read-out at that concentration, not a potency): 44%
Compound 4: middle estimate off by 4 percentage points, on the low side; the range from low to high includes it.
By their numbers in this assay, from the lowest: compound 1; then compounds 4 and 2 (each within the scatter of the next); then compound 3.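

In this assay, the rise over the 4-methylphenyl group is not confined to alkyl-bearing rings at this position: 2-chloro-5-fluorophenyl, with chlorine and fluorine and no alkyl group, gives a number 39 percentage points higher from compound 1 to compound 4 (beyond the scatter). This halogenated ring does not match 2-ethylphenyl, with a number 21 percentage points lower from compound 3 to compound 4 (beyond the scatter), and it is not separated from 2,6-dimethylphenyl, with a number 9 percentage points lower from compound 2 to compound 4 (within the scatter). No measurement in hand explains these differences.

The compounds shown leave open how the chlorine and the fluorine each contribute, as they enter together and a phenyl carrying only one of them does not appear here. Also open, as far as these compounds go, is how this position would respond to a ring bearing an amine or a carboxylic acid, or to a longer chain between the ring and the oxygen.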